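Cyclohexyl for isopropyl on the shared core of compound 2

A few compounds are considered here, and "the series" means these few. Any claim that something is new, unique, unknown or untested is made for them only; others in the source may bear on it.

Measured compounds:
compound 1 `Cc1cc(-c2ccc(F)cc2)c(/C=C/[C@@H]2C[C@@H](O)CC(=O)O2)c(C(C)C)n1`: 9 nM
compound 2 `CC(C)c1nc(-c2ccc(F)cc2)c(/C=C/[C@@H]2C[C@@H](O)CC(=O)O2)c(C(C)C)n1`: 3 nM

In an assay for inhibition of 3-hydroxy-3-methylglutaryl-coenzyme A reductase (Rattus norvegicus) (on this read-out higher numbers stand for weaker inhibition and lower numbers for stronger inhibition), compound 2 gives 3 nM, the lowest number of the two measured compounds. Compound 1 gives 9 nM in this assay, a higher number, and the gap between them lies beyond the scatter. Compound 3 `CC(C)c1nc(C2CCCCC2)nc(-c2ccc(F)cc2)c1/C=C/[C@@H]1C[C@@H](O)CC(=O)O1` is the next compound and has not yet been measured. It differs from compound 2 in one place: cyclohexyl in place of isopropyl on an aromatic carbon. For the measured compounds named here, no measured pair shows this change, so its effect is unknown here. The author expects a step of a 1.3-fold higher number from compound 2 to compound 3 (0.12 log units; within the scatter), most likely not beyond the scatter in either direction. On that basis compound 3 is estimated to give 4 nM in this assay, within a range from 1.5 nM to 12 nM.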

Compound 3, half-maximal inhibitory concentration: 1 nM
Compound 3: the middle estimate sits 4.0-fold (0.60 log units) above what was measured; the whole stated range lies above it.
By their numbers in this assay, from the lowest: compound 3; then compound 2; then compound 1.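

In this assay the change from isopropyl to cyclohexyl on the aromatic carbon between two ring nitrogen atoms gives a 3.0-fold lower number from compound 2 to compound 3 (0.48 log units; beyond the scatter) and so moves the number down by a modest step. For the compounds shown here, this is the first reading of a single change on the shared core: the position takes a six-membered non-aromatic ring of carbon only, with stronger inhibition rather than weaker. Nothing available bears on why the step goes this way.

The compounds shown leave open whether a phenyl ring, a longer chain such as n-butyl, or an amine on this carbon would give a lower or a higher number than cyclohexyl. They also leave open whether the same exchange would give a similar step on another core.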